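Series notes: fluoro for methyl on the shared core

This account rests on a few compounds, and the source may have more. Where it says the series, first, only, none or still open, it means among the compounds named here.

Measured so far:
compound 1 `Cc1ccc2nc(C(=O)Nc3c(F)cc(-c4cccc(F)c4)cc3F)c(C)c(O)c2c1` — 2.34%
compound 2 `Cc1ccc2nc(C(=O)Nc3c(F)cc(-c4cccc(F)c4)cc3F)c(C)c(C(=O)O)c2c1` — 6.34%

In a functional assay on Hep 3B2 cells (Homo sapiens) for antiproliferative activity, read by MTT assay, with a stated time of 24 h, tested at 0.14 ug/mL (a higher number here means a stronger effect of the compound at the concentration tested, a lower number a weaker effect), compound 2 gives 6.34%, which is the top of the two numbers shown; its only neighbour is compound 1 with 2.34%. Going by the values given here, the one measured step, a number 4 percentage points higher from compound 1 to compound 2 (within the scatter), lies within the scatter, so the two compounds are not distinguished by this assay at the concentration tested.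

Compound 3 `Cc1c(C(=O)Nc2c(F)cc(-c3cccc(F)c3)cc2F)nc2ccc(F)cc2c1C(=O)O` is the next member. Relative to compound 2 the change is fluoro in place of methyl on an aromatic carbon. The measured step from compound 1 to compound 2 concerns the carboxy and hydroxy groups on the other ring of the shared core and leaves the site of this change untouched, so it gives no direct guidance on fluoro in place of methyl; it does show that a single small change elsewhere on the core moved the number only within the scatter. With nothing more to go on, no step beyond the scatter is expected here, and the step of a number 0.3 percentage points lower from compound 2 to compound 3 (within the scatter) is meant as an estimate of no real change.

Compound 3 is therefore expected to give about 6% in this assay, in the range 0% to 15%.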

Compound 3, a percentage reported as inhibition, at one concentration (the size of the read-out at that concentration, not a potency): 0.65%
For compound 3 the middle estimate is 5.4 percentage points above the measured one; low and high end bracket the measured number.
By their numbers in this assay, from the lowest: compounds 3, 1 and 2 (each within the scatter of the next).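

In this assay, fluoro in place of methyl on this aromatic carbon, meta to a fused ring and para to a fused ring, gives a number 5.7 percentage points lower from compound 2 to compound 3 (within the scatter), so this first reading at the position does not separate the two groups at the concentration tested. The reading is also a weak test of the position, as compound 2 gives only 6.34% and compound 3 gives 0.65%, leaving little inhibition in either compound against which a loss could show. The data at hand offer no explanation for this result.

Open, on these data alone, is whether a different group at this position, such as an amine, a methoxy group or a chlorine atom, would produce a step beyond the scatter on the shared core. Also open, as far as these compounds go, is whether methyl and fluoro would remain indistinguishable at a concentration where the carboxy compounds give a larger read-out, or across a full range of concentrations.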